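Notes on the step from compound 3 to compound 4

A few compounds are considered here, and "the series" means these few. Any claim that something is new, unique, unknown or untested is made for them only; others in the source may bear on it.

Of the compounds shown here, three sharing one core have been measured in an assay for binding affinity to dual specificity mitogen-activated protein kinase kinase 4 (Homo sapiens), read by KINOMEscan, tested at 100 nM; on this read-out lower numbers stand for a stronger effect and higher numbers for a weaker effect at the one concentration tested. Compound 1 `CCCS(=O)(=O)Nc1ccc(F)c(C(=O)c2n[nH]c3ncc(-c4ccccc4N)cc23)c1F` gives 23%, compound 2 `CCCS(=O)(=O)Nc1ccc(F)c(C(=O)c2n[nH]c3ncc(-c4ccc(C(C)(C)C)cc4)cc23)c1F` gives 46%, and compound 3 `CCCS(=O)(=O)Nc1ccc(F)c(C(=O)c2n[nH]c3ncc(-c4ccc(Cl)c(C(F)(F)F)c4)cc23)c1F` gives 15%. Compound 3 holds the lowest of the three numbers; the gap to compound 1 stays within the scatter, whereas compound 2 lies well apart. The single-point steps are a number 23 percentage points higher from compound 1 to compound 2 (beyond the scatter), a number 8 percentage points lower from compound 1 to compound 3 (within the scatter) and a number 31 percentage points lower from compound 2 to compound 3 (beyond the scatter).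

Compound 4 `CCCS(=O)(=O)Nc1ccc(F)c(C(=O)c2n[nH]c3ncc(-c4ccc(C(N)=O)cc4)cc23)c1F` differs from compound 3 in one place: 4-carbamoylphenyl in place of 4-chloro-3-(trifluoromethyl)phenyl on an aromatic carbon. Among the compounds with values here, no measured step carries the 4-carbamoylphenyl group, so the measured steps bear on it only indirectly. Within the data shown here, the step from compound 2 to compound 3 shows that the aryl group in this place can move the read-out by a large amount, while the step from compound 1 to compound 3 shows that the 2-aminophenyl, the only other measured group carrying a hydrogen-bond donor, stays within the scatter of compound 3. A small rise toward the value of compound 1 is therefore expected, with no confident call beyond the scatter. For compound 4 the expected number is 25%, within a range of 10% to 45%, which is estimated to mean a number 10 percentage points higher from compound 3 to compound 4 (within the scatter).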

Compound 4, a percentage reported as activity, at one concentration (the size of the read-out at that concentration, not a potency): 0.15%
For compound 4 the middle estimate is 24.9 percentage points above the measured one, outside the stated range (below it).
By their numbers in this assay, from the lowest: compound 4; then compounds 3 and 1 (each within the scatter of the next); then compound 2.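

In this assay the 4-carbamoylphenyl group sets this aromatic carbon apart from all the earlier aryl groups, since the number falls beyond the scatter against both 4-chloro-3-(trifluoromethyl)phenyl (a number 14.9 percentage points lower from compound 3 to compound 4 (beyond the scatter)) and 2-aminophenyl (a number 22.9 percentage points lower from compound 1 to compound 4 (beyond the scatter)). Within the data shown here, compound 1 and compound 3 could not be separated, so the earlier set showed only that compound 2 stood apart, whereas carbamoyl in place of tert-butyl on the same phenyl now gives the widest step (a number 45.9 percentage points lower from compound 2 to compound 4 (beyond the scatter)). The entering group carries a hydrogen-bond donor and a hydrogen-bond acceptor where the leaving group carries neither, but nothing available explains the lower number.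

Still open, as far as these compounds go, is whether the amide itself is what matters here, which a carboxylic acid, a nitrile or a methyl ester in place of carbamoyl on the same phenyl would test. Each value is also a read-out at one concentration, so the compounds shown give no potency for any of these aryl groups and no ranking beyond that concentration.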